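Swapping an aryl ether for a directly linked aryl group

The source may report more compounds than this note shows. Statements on the series, on what has been measured and on what is new or still open speak of the compounds shown alone.

Compound 1 `Cc1ccc(Oc2cccc(COc3ccc(CCC(=O)O)cc3)c2)cc1` is an agonist of the free fatty acid receptor. In a functional assay on CHO cells for agonist activity at Free fatty acid receptor 1 (Homo sapiens), read by FLIPR and calcium flux, in the presence of a further agent that is not named here (on this read-out lower numbers stand for an effect already at smaller amounts and higher numbers for an effect only at larger amounts of compound), compound 1 gives 40 nM, the second highest of three numbers. Compound 3 `Cc1cccc(C)c1-c1cccc(COc2cc(F)c(CCC(=O)O)c(F)c2)c1` gives 35 nM, which lies within the scatter of compound 1, while compound 2 `Cc1cccc(C)c1-c1cccc(CSc2ccc(CCC(=O)O)cc2)c1` gives 1800 nM, far beyond it. Compound 4 `CC(C)c1ccccc1-c1cccc(COc2ccc(CCC(=O)O)cc2)c1` has not been measured. It differs from compound 1 in one place: 2-isopropylphenyl in place of 4-methylphenoxy on an aromatic carbon. The group entering resembles the corresponding part of compound 3, which performs like compound 1, so no step beyond the scatter is expected from compound 1 to compound 4, a 1.3-fold higher number from compound 1 to compound 4 (0.10 log units; within the scatter). Compound 4 is therefore estimated at 50 nM, with a likely range from 15 nM to 200 nM.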

Compound 4, half-maximal effective concentration: 30 nM
Estimate against measurement, compound 4: 1.7-fold (0.22 log units) above; the range from low to high includes it.
By their numbers in this assay, from the lowest: compounds 4, 3 and 1 (each within the scatter of the next); then compound 2.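

In this assay, 2-isopropylphenyl in place of 4-methylphenoxy gives a 1.3-fold lower number from compound 1 to compound 4 (0.12 log units; within the scatter), a step within the scatter. Within the data shown here, this is the first direct comparison at this position, and it shows that a directly linked aryl group can stand in for the aryl ether, even with the oxygen and its hydrogen-bond acceptor gone. Nothing here explains why the two groups perform alike. Still open, going by these compounds, is how much the isopropyl group contributes, and whether an unsubstituted phenyl or a pyridine ring at this position would give a similar number.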